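This account rests on a few compounds, and the source may have more. Where it says the series, first, only, none or still open, it means among the compounds named here.

Measured so far in a functional assay on HT-29 cells (Homo sapiens) for antiproliferative activity, read by MTT assay, with a stated time of 24 h; on this read-out lower numbers stand for stronger inhibition and higher numbers for weaker inhibition:

- compound 1 `COc1ccc(C(=O)/C=C/c2cccc(F)c2)c2c1C=CC(C)(C)O2`: > 10000 nM, a limit of the assay, not a number.
- compound 2 `COc1ccc(C(=O)/C=C/c2ccc(N3CCCC3)cc2)c2c1C=CC(C)(C)O2`: 8360 nM.

Compound 1 stands at a limit only: the limit of > 10000 nM in this assay, at which 1 of the 2 values shown sits. Within the data shown here, compound 2 is the one compound of the pair with a numerical reading in this assay, and that reading sits close to where the limit of compound 1 lies. Nothing in these two values places compound 1 with any precision; it can only be said that this assay does not resolve it.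

Compound 3 `COc1ccc(C(=O)/C=C/c2cccc([N+](=O)[O-])c2)c2c1C=CC(C)(C)O2` is not yet measured in this assay. It differs from compound 1 in one place: nitro in place of fluoro on an aromatic carbon. Among the measured compounds shown here, no step between two measured compounds touches this position, so there is nothing to calibrate the change against. The expectation is therefore carried by compound 1 alone, whose reading > 10000 nM is a limit, and by the neighbouring value of compound 2.

The step from compound 1 to compound 3 is expected to stay within the scatter or be small in either direction, as a step that the limit leaves unreadable from compound 1 to compound 3. For compound 3 the estimate in this assay is 12000 nM, with a range from 4000 nM to 40000 nM, and a fair chance that only a limit is reported again.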

Compound 3, half-maximal inhibitory concentration: 4260 nM
Compound 3: middle estimate off by 2.8-fold (0.45 log units), on the high side; the measured number falls inside the stated range.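

In this assay, among these compounds, the change from 3-fluorophenyl to 3-nitrophenyl gives the first readable step at this aromatic carbon, meta to a large group: an at least 2.3-fold lower number from compound 1 to compound 3 (0.37 log units; beyond the scatter). The position therefore responds to substitution, and with nitro in place of fluoro the series gains a numerical reading here, with compound 3 at 4260 nM. The step can be stated only as a minimum and its full size stays unknown, because compound 1 stands at a limit of the assay and not at a number: the limit of > 10000 nM in this assay, at which 1 of the 3 values shown sits.

As far as these compounds go, with a single pair at this position, it remains open whether the step belongs to nitro specifically or whether other replacements of fluoro, such as an amine, a carboxylic acid or a nitrile, would shift the reading in the same direction and to a similar extent. Also open, from the compounds shown here alone, is whether the same change would give a step of similar size on a compound that starts from a numerical reading, which would fix its size, and whether a reading of this order can be improved further by any group at this carbon.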